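This account rests on a few compounds, and the source may have more. Where it says the series, first, only, none or still open, it means among the compounds named here.

Measured compounds in a physicochemical assay for permeability, using PAMPA, at pH 7.4; a higher number here means that the compound crosses the layer faster, a lower number that the compound crosses the layer more slowly:

Compound 1 `CC(C)(C)NC(=O)NCCS(=O)(=O)NC(=O)c1ccc(Nc2nc(NC3(c4ccc(Cl)cc4)CC3)nc(OCC(F)(F)F)n2)cc1` gives 49 nm/s in this assay.
Compound 2 `CC(C)OC(=O)NCCS(=O)(=O)NC(=O)c1ccc(Nc2nc(NC3(c4ccc(Cl)cc4)CC3)nc(OCC(F)(F)F)n2)cc1` gives 71 nm/s in this assay.
Compound 3 `CC(C)(C)CNCCS(=O)(=O)NC(=O)c1ccc(Nc2nc(NC3(c4ccc(Cl)cc4)CC3)nc(OCC(F)(F)F)n2)cc1` gives 651 nm/s in this assay.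

Compound 3 stands highest of the three in this assay; the nearest is compound 2, with a 9.2-fold higher number from compound 2 to compound 3 (0.96 log units; beyond the scatter), and the furthest is compound 1, with a 13-fold higher number from compound 1 to compound 3 (1.12 log units; beyond the scatter). Compound 4 `CC(C)NC(=O)NCCS(=O)(=O)NC(=O)c1ccc(Nc2nc(NC3(c4ccc(Cl)cc4)CC3)nc(OCC(F)(F)F)n2)cc1` is not yet measured. It differs from compound 3 by isopropylcarbamoyl in place of neopentyl on an amine nitrogen. The change runs back toward the pattern of compound 1: an isopropylcarbamoyl group on that nitrogen where compound 1 carries a (tert-butyl)carbamoyl group, so the step from compound 1 to compound 3 is the one that bears most on it, and the step from compound 2 to compound 3 also speaks, as compound 2 carries an isopropoxycarbonyl group on the same nitrogen. Both of those steps were beyond the scatter, while the step of a 1.4-fold higher number from compound 1 to compound 2 (0.16 log units; within the scatter) lay within it. Compound 4 is therefore expected to fall well below compound 3 in this assay, near compound 1 and compound 2, with an expected step of a 13-fold lower number from compound 3 to compound 4 (1.11 log units; beyond the scatter). The estimate for compound 4 is 50 nm/s, with a range from 22 nm/s to 115 nm/s.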

Compound 4, apparent permeability: 45 nm/s
Compound 4: middle estimate off by 1.1-fold (0.05 log units), on the high side; the measured number falls inside the stated range.
By their numbers in this assay, from the lowest: compounds 4, 1 and 2 (each within the scatter of the next); then compound 3.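

In this assay, going by these compounds alone, a third carbonyl-bearing group on the amine nitrogen again sits far below the neopentyl group (a 14-fold lower number from compound 3 to compound 4 (1.16 log units; beyond the scatter)), so compound 3, the only compound here without a carbonyl on that nitrogen, stands apart from the other three. Within that lower group, the change at the carbonyl carbon (a 1.6-fold lower number from compound 2 to compound 4 (0.20 log units; within the scatter)) and the change on the saturated chain carbon (a 1.1-fold lower number from compound 1 to compound 4 (0.04 log units; within the scatter)) both stay within the scatter, so compound 1, compound 2 and compound 4 cannot be ordered. No measurement shown offers a cause for this split.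

The compounds shown leave open whether the high number belongs to neopentyl itself or would also appear with a plain ethyl group or a longer chain on that nitrogen. They also leave open what a simple acetyl group or a carboxylic acid there would give.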